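This account rests on a few compounds, and the source may have more. Where it says the series, first, only, none or still open, it means among the compounds named here.

Compound 2 `COc1cccc(CNCCCNS(=O)(=O)c2cc(C(F)(F)F)cc(C(F)(F)F)c2)c1` stands lowest of the three numbers measured in a functional assay on MCF7 cells (Homo sapiens) for inhibition, read by MTT assay, with a stated time of 72 h; on this read-out higher numbers stand for weaker inhibition of growth and lower numbers for stronger inhibition of growth: in this assay compound 2 gives 2400 nM, while compound 1 `CC(C)(C)c1ccc(CNCCNS(=O)(=O)c2cc(C(F)(F)F)cc(C(F)(F)F)c2)cc1` gives 13000 nM and compound 3 `O=S(=O)(NCCNCc1cccc2ccccc12)c1cc(C(F)(F)F)cc(C(F)(F)F)c1` gives 18000 nM, both beyond the scatter from compound 2. Compound 4 `COc1ccccc1CNCCCNS(=O)(=O)c1cc(C(F)(F)F)cc(C(F)(F)F)c1` has not yet been measured. Going by the values given here, it differs from compound 2 only in the arrangement of the same atoms: 2-methoxyphenyl in place of 3-methoxyphenyl on a saturated chain carbon bound to an amine nitrogen The single measured step, a 1.4-fold higher number from compound 1 to compound 3 (0.14 log units; within the scatter), concerns a different substituent on the same kind of chain carbon and lies within the scatter; no measured pair shows what moving the methoxy group on the phenyl ring does, and compounds 1 and 3 differ from compound 2 in more than this one change. With only a within-scatter step of another kind to go on, the account expects no step beyond the scatter, so compound 4 is estimated at 3000 nM in this assay, with a range of 1200 nM to 8000 nM, which means an expected step of a 1.3-fold higher number from compound 2 to compound 4 (0.10 log units; within the scatter).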

Compound 4, concentration for 50% growth inhibition: 2600 nM
Compound 4: middle estimate off by 1.2-fold (0.06 log units), on the high side, and the stated range covers the measured number.
By their numbers in this assay, from the lowest: compounds 2 and 4 (each within the scatter of the next); then compounds 1 and 3 (each within the scatter of the next).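

In this assay, putting 2-methoxyphenyl in place of 3-methoxyphenyl on a saturated chain carbon bound to an amine nitrogen gives a 1.1-fold higher number from compound 2 to compound 4 (0.03 log units; within the scatter). Going by these compounds alone, this is the only measured pair that isolates where the methoxy group sits on the phenyl ring, and within this pair the two arrangements cannot be told apart, which compounds 1 and 3 could not show. No measured property is at hand that would explain this result.

The compounds shown leave open whether a plain phenyl group or a hydroxyphenyl group on the same chain carbon would also read like compound 2. Compounds 1 and 3 each differ from compound 2 in more than one place, so the effect of the chain between the two nitrogens, or of a longer chain, also remains unread.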